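One Methyl Group, Two Cores, and Cell Growth Inhibition

The source may hold more compounds than are shown below. What is called first, only, known or untested is meant among the compounds shown, and "the series" means these compounds.

Measured so far, in a functional assay on MCF7 cells (Homo sapiens) for cytotoxicity, read by MTT assay, with a stated time of 72 h, tested at 30 uM; a higher number here means more inhibition of growth at the concentration tested, a lower number less inhibition of growth:
- compound 1, `N/C(=N\NC(=S)N1CCCCCC1)c1ccccn1`, gives 76.5%
- compound 2, `N/C(=N\NC(=S)N1CCCCC1)c1ccccn1`, gives 69.3%
- compound 3, `Cc1cccc(/C(N)=N/NC(=S)N2CCCCCC2)n1`, gives 38.8%

Compound 3 is compound 1 with one change, (methyl in place of hydrogen on an aromatic carbon), and this change made the step of a number 37.7 percentage points lower from compound 1 to compound 3 (beyond the scatter). The difference between the core of compound 1 and the core of compound 2 is not broken down here; their values lie within the scatter of each other, while the value of compound 2 lies beyond the scatter from that of compound 3.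

Compound 4, `Cc1ccnc(/C(N)=N/NC(=S)N2CCCCC2)c1`, is not yet measured. It comes from compound 2 by methyl in place of hydrogen on an aromatic carbon. Among the measured compounds shown here, this is the same kind of change as the one from compound 1 to compound 3, but not the same: in compound 3 the methyl sits next to the ring nitrogen, whereas in compound 4 it sits opposite the ring nitrogen. For the measured compounds named here, for this assay the expected step is a number 27.3 percentage points lower from compound 2 to compound 4 (beyond the scatter), because the only measured example of this kind of change gave a number 37.7 percentage points lower from compound 1 to compound 3 (beyond the scatter), and the different place around the methyl adds uncertainty. Compound 4 is therefore estimated at 42%, most likely between 22% and 62%.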

Compound 4, percent growth inhibition at one concentration: 61.7%
The estimate for compound 4 lay 19.7 percentage points below the measured number; measured number inside the range.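

In this assay, methyl in place of hydrogen on an aromatic carbon gave a number 7.6 percentage points lower from compound 2 to compound 4 (within the scatter). The size of the step therefore did not carry over from one core to the other, and a single measured step proved a poor guide to the next one in this series: the same change on two cores in this assay, a number 37.7 percentage points lower (beyond the scatter) from compound 1 to compound 3 and a number 7.6 percentage points lower (within the scatter) from compound 2 to compound 4, 30.1 percentage points apart, beyond the scatter of two such steps. This does not show whether the core or the place of the methyl accounts for the gap: the two pairs differ in both, with the methyl of compound 4 opposite the ring nitrogen and that of compound 3 elsewhere on the ring.

The compounds shown leave open what a methyl would do in the same place on both cores, which is the comparison that would separate these two differences. They also leave open whether an ethyl group, a methoxy group or a chlorine atom in these places would give steps that differ between the cores in the same way.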